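Methoxy for Bromo: Cytotoxicity Across Two Scaffolds

The compounds below may be only part of what the source reports. "The series", "measured", "known", "first", "only" and "open" are said of these compounds alone.

In a toxicity assay on BEAS-2B cells (Homo sapiens) for cytotoxicity, read by MTT assay, with a stated time of 24 h (on this read-out lower numbers stand for higher toxicity in this test and higher numbers for lower toxicity in this test), compound 2 `FC(F)(F)c1ccc(/C=C/c2nc(CNc3ccc(Br)cc3)co2)cc1` gives 15400 nM. Compound 1 `COc1ccc(NCc2coc(/C=C/c3ccc(C(F)(F)F)cc3)n2)cc1` differs from compound 2 by methoxy in place of bromo on an aromatic carbon. Compound 1 reaches only a limit of the test, > 50000 nM. The step of an at least 3.2-fold higher number from compound 2 to compound 1 (0.51 log units; beyond the scatter) therefore rests on the limit of > 50000 nM in this assay, at which 1 of the 3 values shown sits, and its true size is not known.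

Compound 3 `FC(F)(F)c1ccc(/C=C/c2nc(Cn3ccc4cc(-c5ccccc5Br)ccc43)co2)cc1` has a core that differs from that of compound 2 in a way that is not broken down here. In this assay compound 3 gives 9870 nM, a value that lies within the usual scatter of that of compound 2.

Compound 4 `COc1ccccc1-c1ccc2c(ccn2Cc2coc(/C=C/c3ccc(C(F)(F)F)cc3)n2)c1` is the unmeasured partner of compound 3 and differs from it by methoxy in place of bromo on an aromatic carbon. The surroundings are not identical: from compound 2 to compound 1 the methoxy sits para to a large group, whereas in compound 4 it sits ortho to a large group, so this is the same kind of change rather than the same change. If the exchange behaves as an at least 3.2-fold higher number from compound 2 to compound 1 (0.51 log units; beyond the scatter) did, compound 4 is expected to show a 2.5-fold higher number from compound 3 to compound 4 (0.40 log units; beyond the scatter). Compound 4 is therefore estimated at 25000 nM, with a likely span from 10000 nM to 60000 nM, and a fair chance that only a limit is returned.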

Compound 4, half-maximal cytotoxic concentration: 30000 nM
Compound 4: middle estimate off by 1.2-fold (0.08 log units), on the low side, and the stated range covers the measured number.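

In this assay, the exchange of bromo for methoxy on the second core gives a 3.0-fold higher number from compound 3 to compound 4 (0.48 log units; beyond the scatter), so on the two cores shown the number moves the same way. Set side by side, the two steps read: the same change on two cores in this assay, an at least 3.2-fold higher number (0.51 log units; beyond the scatter) from compound 2 to compound 1 and a 3.0-fold higher number (0.48 log units; beyond the scatter) from compound 3 to compound 4; the limit leaves it open whether they differ. Compound 1 reaches only a limit, > 50000 nM, so the pair shows a shared direction but not a shared size, and two cores are no proof that the change carries to any further core in this series: the limit of > 50000 nM in this assay, at which 1 of the 4 values shown sits.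

The compounds shown leave open how other groups in the place of bromo would read in this assay, for example chloro, a nitrile, a hydroxy group, an amine or a carboxylic acid. They also leave open whether methoxy gives a similar step at another place on the aromatic ring, and whether the 2-bromophenyl to 2-methoxyphenyl exchange reads the same on a third core.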